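Swapping an Acetyl Group: From Compound 2 to Compound 3

This account rests on a few compounds, and the source may have more. Where it says the series, first, only, none or still open, it means among the compounds named here.

Measured compounds:
compound 1 `O=C(CCCCC1CCSS1)NCc1cn(CCCOc2ccc3ccc(=O)oc3c2)nn1`: 42.2%
compound 2 `CC(=O)c1cc2ccc(OCCCCCn3cc(CNC(=O)CCCCC4CCSS4)nn3)cc2oc1=O`: 20.7%

In a functional assay on PC-12 cells (Rattus norvegicus) for cytotoxicity, read by MTT assay, with stated times of 3 h and 2 h, tested at 20 uM (a lower number here means a weaker effect, a higher number a stronger effect of the compound at the concentration tested), compound 2 gives 20.7%, the lower of the two numbers, while compound 1 gives 42.2%, a gap beyond the scatter. Compound 3 `COc1ccc(-c2cc3ccc(OCCCCCn4cc(CNC(=O)CCCCC5CCSS5)nn4)cc3oc2=O)cc1OC` differs from compound 2 in one place: 3,4-dimethoxyphenyl in place of acetyl on an aromatic carbon. For the measured compounds named here, no step between measured compounds shows the effect of such a change, so the expectation rests on compound 2 alone. A small shift is expected, estimated as a number 7.3 percentage points higher from compound 2 to compound 3 (within the scatter), likely within the scatter. Compound 3 is therefore expected to give 28%, with a range from 10% to 50%.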

Compound 3, a percentage reported as activity, at one concentration (the size of the read-out at that concentration, not a potency): 51.9%
Compound 3: the middle estimate sits 23.9 percentage points below what was measured; measured number outside the range, above it.
By their numbers in this assay, from the lowest: compound 2; then compounds 1 and 3 (each within the scatter of the next).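

In this assay, the aromatic carbon two atoms from the ring oxygen proves sensitive to what it carries: 3,4-dimethoxyphenyl in place of acetyl gives a number 31.2 percentage points higher from compound 2 to compound 3 (beyond the scatter) and so the step is large. The earlier compounds shown here differed in more than one place and could not isolate this position.

As far as these compounds go, whether the step depends on the added aromatic ring or on its two methoxy groups stays open. So does what an unsubstituted phenyl or an amine would give at this carbon. Nothing presented here explains the step.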